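Changing the aryl group on the ring amine nitrogen

The source may report more compounds than this note shows. Statements on the series, on what has been measured and on what is new or still open speak of the compounds shown alone.

compound 1: `Nc1scc(CN2CCN(c3cc(Cl)cc(Cl)c3)CC2)c1C(=O)c1ccc(Cl)cc1`, 1%
compound 2: `Nc1scc(CN2CCN(c3ccc(Cl)cc3F)CC2)c1C(=O)c1ccc(Cl)cc1`, 0%
compound 3: `Nc1scc(CN2CCN(c3ccc([N+](=O)[O-])cc3)CC2)c1C(=O)c1ccc(Cl)cc1`, 1%

In an assay on CHO cells for displacement of a labelled ligand from adenosine receptor A1 (Homo sapiens), read by scintillation counting, with a stated time of 120 min, tested at 10 uM (on this read-out higher numbers stand for more inhibition at the one concentration tested (going by the name of the read-out) and lower numbers for less inhibition), compound 1 stands level with compound 3 at the digits printed, the two together the highest of the three numbers; the step of no change at the digits printed from compound 1 to compound 3 (within the scatter) and the step of a number 1 percentage points lower from compound 1 to compound 2 (within the scatter) both lie within the scatter. Compound 4 `Nc1scc(CN2CCN(c3ccccc3C(F)(F)F)CC2)c1C(=O)c1ccc(Cl)cc1` carries a different aryl group on the same nitrogen: 2-(trifluoromethyl)phenyl in place of 3,5-dichlorophenyl on an amine nitrogen in a ring. Among the measured compounds shown here, the steps that bear on this change are the three aryl swaps at that nitrogen, a number 1 percentage points lower from compound 1 to compound 2 (within the scatter), no change at the digits printed from compound 1 to compound 3 (within the scatter) and a number 1 percentage points higher from compound 2 to compound 3 (within the scatter), each within the scatter. No step beyond the scatter is therefore expected in this assay. Compound 4 is expected to give 1%, between -8% and 10%, a step of no change at the digits printed from compound 1 to compound 4 (within the scatter).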

Compound 4, a percentage reported as inhibition, at one concentration (the size of the read-out at that concentration, not a potency): 0%
For compound 4 the middle estimate is 1 percentage points above the measured one, and the stated range covers the measured number.
By their numbers in this assay, from the lowest: compounds 2, 4, 1 and 3 (each within the scatter of the next).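

In this assay, the 2-(trifluoromethyl)phenyl group on the ring amine nitrogen stays within the scatter of all three earlier aryl groups (a number 1 percentage points lower from compound 1 to compound 4 (within the scatter)) (a number 1 percentage points lower from compound 3 to compound 4 (within the scatter)) (no change at the digits printed from compound 2 to compound 4 (within the scatter)). The flat picture at this position, so far seen with chlorine, fluorine and nitro substituents, thus also holds for a trifluoromethyl group on the aryl ring. No measurement given here accounts for this flat read-out.

As far as these compounds go, whether an aryl ring bearing an amine or a carboxylic acid would give a different number remains open. So does the effect of a benzyl group on that nitrogen.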